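This account rests on a few compounds, and the source may have more. Where it says the series, first, only, none or still open, it means among the compounds named here.

Compound 1, `Cc1ccc2c(c1)C(=O)C(=O)N2CCCOC(=O)c1cn(C2CC2)c2cc(N3CCN(CCCN4C(=O)C(=O)c5cc(C)ccc54)CC3)c(F)cc2c1=O`, in an ADME assay on Vero cells (Chlorocebus sabaeus) for cytotoxicity, read by MTT assay, with a stated time of 72 h (a lower number here means that less compound is tolerated, a higher number that more compound is tolerated), gives 64 ug/mL.
Compound 2, `CCO/N=C1\C(=O)N(CCCN2CCN(c3cc4c(cc3F)c(=O)c(C(=O)O)cn4C3CC3)CC2)c2ccccc21`, in this assay gives 64 ug/mL.
Compound 3, `CCO/N=C1\C(=O)N(CCCN2CCN(c3cc4c(cc3F)c(=O)c(C(=O)O)cn4C3CC3)CC2)c2ccc(C)cc21`, in this assay gives 128 ug/mL.

Compound 2 stands level with compound 1 at the digits reported, and the two together are the lowest of the three numbers in this assay. Its nearest neighbour is compound 1, with no change at the digits reported, and its furthest is compound 3, reached by a 2.0-fold higher number from compound 2 to compound 3 (0.30 log units; within the scatter), which is within the scatter.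

Compound 4, `CO/N=C1\C(=O)N(CCCN2CCN(c3cc4c(cc3F)c(=O)c(C(=O)O)cn4C3CC3)CC2)c2ccccc21`, differs from compound 2 in a single place: hydrogen in place of methyl on a saturated chain carbon bound to an oxygen on an unsaturated carbon. It has not yet been measured in this assay.

For the measured compounds named here, only one measured step bears on this change. It is a 2.0-fold higher number from compound 2 to compound 3 (0.30 log units; within the scatter), where a methyl was gained or lost on an aromatic carbon rather than on a saturated chain carbon, and it stayed within the scatter. The change from compound 2 to compound 4 is of the same size in atoms, a single carbon, at a different place. With no measured step beyond the scatter for a one-carbon change in this series, compound 4 is expected to sit where compound 2 sits, with no change at the digits printed from compound 2 to compound 4 (within the scatter) meaning no step beyond the scatter. The estimate for compound 4 in this assay is 64 ug/mL, in the range 32 ug/mL to 128 ug/mL.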

Compound 4, half-maximal cytotoxic concentration: 32 ug/mL
Compound 4: the middle estimate sits 2.0-fold (0.30 log units) above what was measured; low and high end bracket the measured number.
By their numbers in this assay, from the lowest: compounds 4, 1, 2 and 3 (each within the scatter of the next, the first and the last beyond it).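

For the compounds shown here, the ethoxy to methoxy change gives the first measured step at this place, a saturated chain carbon bound to an oxygen on an unsaturated carbon: in this assay, the step is a 2.0-fold lower number from compound 2 to compound 4 (0.30 log units; within the scatter). Going by these compounds alone, until now, the only step concerned a methyl on an aromatic carbon, so the result adds a second place where gaining or losing a methyl stays within the usual scatter, and the read-out at this place does not separate the ethyl from the methyl end of the chain. Nothing in the data given here accounts for the result, and the step is too small to call for an explanation in any case.

What the compounds shown leave open is how far this tolerance extends, since a longer chain such as propyl, a branched isopropyl, a benzyl group or a chain ending in an amine or a carboxylic acid would test the same place with a larger change than this one. They also leave open whether the methoxy group and the aromatic methyl would together give a number different from either single change.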